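Extending the polyamine tail of a trimethoxychalcone

The source may report more compounds than this note shows. Statements on the series, on what has been measured and on what is new or still open speak of the compounds shown alone.

Compound 1 `COc1ccc(/C=C/C(=O)c2cc(OC)c(OC)c(OC)c2)cc1OCCCC(=O)NCCCNCCCCNCCN`: 31800 nM
Compound 2 `COc1cc(C(=O)/C=C/c2ccc(OCCCC(=O)NCCCNCCCCN)cc2)cc(OC)c1OC`: a limit, > 100000 nM
Compound 3 `COc1ccc(/C=C/C(=O)c2cc(OC)c(OC)c(OC)c2)cc1OCCCC(=O)NCCCCN(CCCN)CCCCN`: 60600 nM

In a functional assay on PC-3 cells (Homo sapiens) for antiproliferative activity, read by MTT assay, with a stated time of 48 h (on this read-out lower numbers stand for stronger inhibition and higher numbers for weaker inhibition), compound 3 gives 60600 nM, the highest of the two numbers recorded there. Its nearest neighbour is compound 1, which in this assay gives 31800 nM, and the step of a 1.9-fold higher number from compound 1 to compound 3 (0.28 log units; within the scatter) lies within the scatter. Compound 2 reaches only a limit, (the limit of > 100000 nM in this assay, at which 1 of the 3 values shown sits), so it supplies no number for comparison.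

Compound 4 `COc1ccc(/C=C/C(=O)c2cc(OC)c(OC)c(OC)c2)cc1OCCCC(=O)NCCCCN(CCCN)CCCCNCCCN` differs from compound 3 by 3-aminopropyl in place of hydrogen on an amine nitrogen. Among the compounds with values here, no measured step covers this exact change; the single step available, from compound 1 to compound 3, rearranges the tail without adding to it and stays within the scatter, so it gives little guidance about growing the chain. Compound 2 and compound 1 show that a shorter tail gave a limit while a longer one gave a number, which is the only hint that a longer tail might lower the number. For compound 4 the expected step is a 1.3-fold lower number from compound 3 to compound 4 (0.13 log units; within the scatter), and the estimate is 45000 nM, within a range of 15000 nM to 150000 nM.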

Compound 4, half-maximal inhibitory concentration: 48100 nM
Compound 4: the middle estimate sits 1.1-fold (0.03 log units) below what was measured, and the stated range covers the measured number.
By their numbers in this assay, from the lowest: compounds 1, 4 and 3 (each within the scatter of the next). At a limit, above all of these: compound 2.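

Putting 3-aminopropyl in place of hydrogen on an amine nitrogen gives, in this assay, a 1.3-fold lower number from compound 3 to compound 4 (0.10 log units; within the scatter). This is the first step shown that adds to the tail rather than rearranging it, and it shows that at this nitrogen the added 3-aminopropyl, with its 4 heavy atoms, does not carry the read-out beyond the scatter. Nothing shown here bears on the reason for this outcome.

On these data alone, whether a longer chain or a carboxylic acid in place of this 3-aminopropyl would carry the number beyond the scatter remains open. So does whether 3-aminopropyl on a different amine nitrogen of the tail would give a step of similar size.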